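The source may hold more compounds than are shown below. What is called first, only, known or untested is meant among the compounds shown, and "the series" means these compounds.

Measured compounds in an ADME assay on HUVEC cells (Homo sapiens) for antiproliferative activity, read by MTT assay, with a stated time of 48 h; on this read-out higher numbers stand for weaker inhibition and lower numbers for stronger inhibition:

- compound 1, `N#CC1=C(N)Oc2c(c3nc4ccccc4nc3c3ccccc23)C12C(=O)N(Cc1cnnn1-c1ccccc1Br)c1ccccc12`: compound 1 gives > 50000 nM, which is a limit of the assay and not a number.
- compound 2, `N#CC1=C(N)Oc2c(c3nc4ccccc4nc3c3ccccc23)C12C(=O)N(Cc1cnnn1-c1cccc(S(N)(=O)=O)c1)c1ccccc12`: compound 2 gives 38600 nM.
- compound 3, `CCOc1ccc(-n2nncc2CN2C(=O)C3(C(C#N)=C(N)Oc4c(N)cc5nc6ccccc6nc5c43)c3ccccc32)cc1`: compound 3 gives > 50000 nM, again a limit of the assay rather than a number.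

Where compound 3 stands: only a limit is known for it in this assay, and it sits at the limit of > 50000 nM in this assay, at which 2 of the 3 values shown sit, together with compound 1. Going by the values given here, compound 2 is the only member of the series with a number, and the one step measured at the aryl group on the aromatic nitrogen, an at least 1.2-fold lower number from compound 1 to compound 2 (0.11 log units; that floor lies within the scatter), is a change from one limit to a number just past it, so it lies within the scatter.

Compound 4, `N#CC1=C(N)Oc2c(N)cc3nc4ccccc4nc3c2C12C(=O)N(Cc1cnnn1-c1ccc(Cl)cc1[N+](=O)[O-])c1ccccc12`, differs from compound 3 by 4-chloro-2-nitrophenyl in place of 4-ethoxyphenyl on an aromatic nitrogen. Among the compounds with values here, that change sits on the same aromatic nitrogen as the one measured step, but the groups leaving and entering are different from those of that step, so the measured step bears on it only loosely; it gives no sign of a move beyond the scatter in either direction. The expected step of a number no higher from compound 3 to compound 4 (the limit leaves the size open) is therefore no step beyond the scatter. Compound 4 is estimated at 50000 nM in this assay, with a range from 20000 nM to 120000 nM, and it is expected most likely to be reported as a limit only.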

Compound 4, half-maximal inhibitory concentration: > 50000 nM
Compound 4 gave a limit, no number; the forecaster's own chance of this, stated with the estimate: 70%; the middle value lies on the limit itself.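

In this assay compound 3 and compound 4 both sit at a limit of the assay and not at a number, so no step can be read between them: the limit of > 50000 nM in this assay, at which 3 of the 4 values shown sit.

The compounds shown leave open where the true values of compound 3 and compound 4 lie, and whether 4-chloro-2-nitrophenyl and 4-ethoxyphenyl differ at all on this read-out.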